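The compounds below may be only part of what the source reports. "The series", "measured", "known", "first", "only" and "open" are said of these compounds alone.

Compound 2 `CC(C)CN(c1cccc(F)c1)S(=O)(=O)c1ccc2c(c1)C(=O)CC(C1CCOCC1)O2` stands highest of the two measured compounds in a physicochemical assay for lipophilicity, at pH 7.4 (on this read-out higher numbers stand for higher lipophilicity and lower numbers for lower lipophilicity), at 3.5, while compound 1 `CC(C)CN(c1ccc(C#N)cc1)S(=O)(=O)c1ccc2c(c1)C(=O)CC(C1CCOCC1)O2` gives 3.16. Going by the values given here, the only measured step, a number 0.34 log units higher from compound 1 to compound 2 (beyond the scatter), is modest but beyond the scatter, and it changed the same place. Compound 3 `CC(C)CN(c1ccc(C(C)(C)C)cc1)S(=O)(=O)c1ccc2c(c1)C(=O)CC(C1CCOCC1)O2` carries 4-(tert-butyl)phenyl in place of 3-fluorophenyl on a sulfonamide nitrogen. Among the compounds with values here, no measured step involves this group, so that single step is only a rough guide to size. In this assay, a rise larger than that step is expected, an estimated a number 0.80 log units higher from compound 2 to compound 3 (beyond the scatter). The expected value for compound 3 is 4.3, with an estimated range of 3.8 to 4.8.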

Compound 3, distribution coefficient: 4.97
Compound 3: the middle estimate sits 0.67 log units below what was measured; the whole stated range lies below it.
By their numbers in this assay, from the lowest: compound 1; then compound 2; then compound 3.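

In this assay, the aryl group on the sulfonamide nitrogen can shift the read-out much further than the earlier modest step showed: a number 1.47 log units higher from compound 2 to compound 3 (beyond the scatter), with 4-(tert-butyl)phenyl in place of 3-fluorophenyl. Tert-butyl in place of cyano on an aromatic carbon gives the widest span among these compounds, a number 1.81 log units higher from compound 1 to compound 3 (beyond the scatter). Nothing available explains the size of these steps. Where a methyl group or a carboxylic acid on that aromatic carbon would fall remains open. So does whether a step of this size would persist with a different group on the sulfonamide nitrogen in place of the saturated chain.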